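Phthalazinone pyrazolylamines: benzyl to methyl on the ring nitrogen

A few compounds are considered here, and "the series" means these few. Any claim that something is new, unique, unknown or untested is made for them only; others in the source may bear on it.

Measured compounds:
- compound 1 `O=c1c2ccccc2c(Nc2n[nH]c3ccccc23)nn1-c1ccccc1`: "not determined" (no result reported)
- compound 2 `COc1ccc(Cn2nc(Nc3cc(C)[nH]n3)c3ccccc3c2=O)cc1`: 1200 nM
- compound 3 `CC(=O)Nc1ccc(Cn2nc(Nc3cc(C)[nH]n3)c3ccccc3c2=O)cc1`: 4200 nM

In a functional assay on HCT-116 cells (Homo sapiens) for cytotoxicity, read by CellTiter-Glo, with a stated time of 5 days (a higher number here means a weaker inhibitor, a lower number a stronger inhibitor), compound 2 gives 1200 nM, the lower of the two numbers available; compound 3 gives 4200 nM, and the step of a 3.5-fold higher number from compound 2 to compound 3 (0.54 log units; beyond the scatter) is the only measured one, brought about by acetamido in place of methoxy on an aromatic carbon. Compound 1 carries a different arylamine and a phenyl on the ring nitrogen, and in this assay compound 1 gives "not determined" (no result reported).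

Compound 4 `Cc1cc(Nc2nn(C)c(=O)c3ccccc23)n[nH]1` is the next member. It differs from compound 2 by hydrogen in place of 4-methoxyphenyl on a saturated chain carbon bound to an aromatic nitrogen; cut one bond further out, the change reads 4-methoxybenzyl to methyl. Within the data shown here, none of the measured steps touches this part of the molecule: the one step available alters the methoxy on the benzyl ring, whereas here the whole 4-methoxyphenyl is taken away. That step was modest, so the region is not indifferent to change, and the loss of the full group is a larger alteration than a swap at its far end. A weakening beyond the scatter is therefore expected in this assay, with wide uncertainty. For compound 4 the expected step is a 3.3-fold higher number from compound 2 to compound 4 (0.52 log units; beyond the scatter), and the estimate is 4000 nM with a range of 1500 nM to 12000 nM.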

Compound 4, half-maximal inhibitory concentration: 5200 nM
For compound 4 the middle estimate is 1.3-fold (0.11 log units) below the measured one; low and high end bracket the measured number.
By their numbers in this assay, from the lowest: compound 2; then compounds 3 and 4 (each within the scatter of the next).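

In this assay, among these compounds, cutting the 4-methoxybenzyl group on the ring nitrogen back to methyl gives a 4.3-fold higher number from compound 2 to compound 4 (0.64 log units; beyond the scatter), the first reading of the whole 4-methoxyphenyl at this place rather than of a swap at its far end. Activity survives the loss of that group: compound 4 still gives 5200 nM, within the scatter of compound 3 at 4200 nM, so in this assay removing the 4-methoxyphenyl and replacing methoxy with acetamido leave these two compounds at one level. The data offer no measurement that accounts for the step.

Open, going by these compounds, is whether the advantage of compound 2 over compound 4 depends on the aromatic ring, on the methoxy group or only on the size of the group at this place; unsubstituted benzyl, cyclohexylmethyl and a longer alkyl chain such as n-butyl would separate these readings. Also open, on these data alone, is how the shared core behaves with only hydrogen on the ring nitrogen, and whether a carboxylic acid or an amine on the benzyl ring would hold the level of compound 2.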